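Extending the acyl chain on a trimethoxyphenyl amide

This account rests on a few compounds, and the source may have more. Where it says the series, first, only, none or still open, it means among the compounds named here.

Compound 1 `CCC(=O)N(Cc1ccc(OC)c(O)c1)c1cc(OC)c(OC)c(OC)c1` carries a propanoyl group on the amide-type nitrogen of the shared core. In a functional assay on HCT-116 cells (Homo sapiens) for inhibition, read by MTT assay, with a stated time of 48 h (on this read-out lower numbers stand for stronger inhibition and higher numbers for weaker inhibition), compound 1 gives 61 nM, the lowest of the two numbers recorded here. Compound 2 `COc1ccc(CNc2cc(OC)c(OC)c(OC)c2)cc1Br`, which lacks the acyl group and holds a secondary amine in its place, gives 48100 nM in this assay, a far higher number that lies well beyond the scatter of the method. Compound 3 `COc1cc(NCc2ccc(Cl)cc2)cc(OC)c1OC` is reported in this assay as > 80000 nM, which is a limit of the assay rather than a number; it sits at the limit of > 80000 nM in this assay, at which 1 of the 3 values shown sits.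

Compound 4 `CC/C=C/C(=O)N(Cc1ccc(OC)c(O)c1)c1cc(OC)c(OC)c(OC)c1` has not yet been measured. It differs from compound 1 in a single place: but-1-en-1-yl in place of ethyl on a carbonyl carbon. The same difference, cut one bond further out, reads propanoyl to (but-1-en-1-yl)carbonyl. Among the measured compounds shown here, no measured pair in this set shows such a change, so the size of its effect in this assay is uncertain. The acyl group is retained, and the amine compound 2 shows how much the number rises when it is absent. The expected step of a 1.2-fold higher number from compound 1 to compound 4 (0.09 log units; within the scatter) is therefore small, within the scatter, with no clear direction. Compound 4 is expected to give about 75 nM in this assay, estimated between 25 nM and 250 nM.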

Compound 4, half-maximal inhibitory concentration: 63 nM
For compound 4 the middle estimate is 1.2-fold (0.08 log units) above the measured one; low and high end bracket the measured number.
By their numbers in this assay, from the lowest: compounds 1 and 4 (each within the scatter of the next); then compound 2. At a limit, above all of these: compound 3.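

The result shows that this position, on a carbonyl carbon whose other neighbour is the amide-type nitrogen, accommodates a substantial change of substituent without any measurable effect: in this assay, the replacement of ethyl by but-1-en-1-yl gives a 1.0-fold higher number from compound 1 to compound 4 (0.01 log units; within the scatter). The entering group goes from 2 to 4 heavy atoms and brings 1 double bond outside aromatic rings, so the earlier compounds, none of which varied the acyl group while keeping it in place, could not have shown that the number holds through such a step. No measurement shown here accounts for this outcome.

Chain length and the double bond enter together in this one step, and the compounds shown do not separate them; a saturated butyl chain on the same carbonyl carbon would be the group to read that. Going by these compounds, how far the position stays this permissive also remains open, since the effect of a much longer chain, a phenyl ring, or a chain ending in an amine or a carboxylic acid on this carbonyl carbon cannot be told from these compounds.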